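The compounds below may be only part of what the source reports. "The series", "measured", "known", "first", "only" and "open" are said of these compounds alone.

Compound 3 `CCn1c(C(=O)NC(C)(C)CO)ccc1C(CC)(CC)c1ccc(OCS(=O)(=O)c2ccccc2)c(C)c1` gives 18300 nM in a functional assay on BXPC-3 cells (Homo sapiens) for antiproliferative activity, read by MTT assay, with a stated time of 24 h; on this read-out lower numbers stand for stronger inhibition and higher numbers for weaker inhibition. It is the higher of the two numbers shown, with compound 2 `CCn1c(C(=O)N[C@@H](C)CO)ccc1C(CC)(CC)c1ccc(OCS(=O)(=O)c2ccccc2)c(C)c1` nearest at 15300 nM, and a 1.2-fold higher number from compound 2 to compound 3 (0.08 log units; within the scatter). Compound 1 `CCn1c(C(=O)N[C@H](C)C(=O)OC)ccc1C(CC)(CC)c1ccc(OCS(=O)(=O)c2ccccc2)c(C)c1` returns only a limit in this assay, > 50000 nM (the limit of > 50000 nM in this assay, at which 1 of the 3 values shown sits). The moves away from that ester were an at least 3.2-fold lower number from compound 1 to compound 2 (0.51 log units; beyond the scatter) and an at least 2.7-fold lower number from compound 1 to compound 3 (0.43 log units; beyond the scatter).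

Compound 4 `CCn1c(C(=O)NCC(=O)O)ccc1C(CC)(CC)c1ccc(OCS(=O)(=O)c2ccccc2)c(C)c1` carries carboxymethyl in place of 1-(hydroxymethyl)-1-methylethyl on an amide-type nitrogen. For the measured compounds named here, no measured step in this assay exchanges a hydroxymethyl-bearing substituent for a carboxymethyl group, so the two alcohol steps and the ester limit only frame the range, and the change in this assay is expected to be small or none beyond the scatter, if anything toward a higher number. Compound 4 is expected at 25000 nM, between 9000 nM and 70000 nM. The expected step is a 1.4-fold higher number from compound 3 to compound 4 (0.14 log units; within the scatter).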

Compound 4, half-maximal inhibitory concentration: > 50000 nM
Compound 4: no number, only a limit; the forecaster's own chance of this, stated with the estimate: 30%; middle value at least 2.0-fold (0.30 log units) away from the limit.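

Carboxymethyl on the amide-type nitrogen does not keep the readable values of the two hydroxymethyl-bearing substituents in this assay, with an at least 2.7-fold higher number from compound 3 to compound 4 (0.43 log units; beyond the scatter) and an at least 3.2-fold higher number from compound 2 to compound 4 (0.51 log units; beyond the scatter) as the steps. Compound 4 gives only a limit, and compound 1 shares it: the limit of > 50000 nM in this assay, at which 2 of the 4 values shown sit. The step between these two cannot be read, so they stay unranked.

Going by these compounds, what an amine or a longer hydroxyalkyl chain on this nitrogen would give stays open. Also open, on these data alone, is whether any group here reaches a clearly lower number than compound 2 at 15300 nM on the same core.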